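Swapping the N-terminal Side Chain of a Nucleoside Prodrug

The source may hold more compounds than are shown below. What is called first, only, known or untested is meant among the compounds shown, and "the series" means these compounds.

Measured so far:
compound 1 `CCCCCc1ccc(-c2cc3cn([C@H]4C[C@H](O)[C@@H](COC(=O)[C@@H](NC(=O)[C@@H]5CCCN5C(=O)[C@@H](N)C(C)C)C(C)C)O4)c(=O)nc3o2)cc1`: > 100000 nM
compound 2 `CCCCCc1ccc(-c2cc3cn([C@H]4C[C@H](O)[C@@H](COC(=O)[C@H](C)NC(=O)[C@@H]5CCCN5C(=O)[C@@H](N)C(C)C)O4)c(=O)nc3o2)cc1`: 44000 nM

Compound 1 gives only a limit of the assay in an ADME assay on HEL cells (Homo sapiens) for inhibition (a higher number here means that more compound is tolerated, a lower number that less compound is tolerated), (the limit of > 100000 nM in this assay, at which 1 of the 2 values shown sits). Compound 3 `CCCCCc1ccc(-c2cc3cn([C@H]4C[C@H](O)[C@@H](COC(=O)[C@@H](NC(=O)[C@@H]5CCCN5C(=O)[C@@H](N)CC(N)=O)C(C)C)O4)c(=O)nc3o2)cc1` differs from it by carbamoylmethyl in place of isopropyl on a saturated chain carbon bound to an amine nitrogen and a carbonyl carbon. Within the data shown here, the one measured step, an at least 2.2-fold lower number from compound 1 to compound 2 (0.35 log units; beyond the scatter), concerns a different position, so it does not speak to this change. Compound 3 is therefore expected to stay close to compound 1, with a number no higher from compound 1 to compound 3 (the limit leaves the size open) and an estimated value of 100000 nM, between 40000 nM and 300000 nM.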

Compound 3, half-maximal cytotoxic concentration in the HEL assay: 56000 nM
For compound 3 the middle estimate is 1.8-fold (0.25 log units) above the measured one, and the stated range covers the measured number.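

From the compounds shown here alone, in the HEL assay, carbamoylmethyl in place of isopropyl on a saturated chain carbon bound to an amine nitrogen and a carbonyl carbon gives an at least 1.7-fold lower number from compound 1 to compound 3 (0.25 log units; that floor lies within the scatter), and the true size of this step stays unknown, since compound 1 stands at a limit of the assay: the limit of > 100000 nM in the HEL assay, at which 1 of the 3 values shown sits. In a physicochemical assay for solubility, with a stated time of 24 h (a higher number here means a more soluble compound, a lower number a less soluble compound), compound 1 gives 1200 ug/mL and compound 3 gives 39000 ug/mL. Among these compounds, the same change gives the first reading at this position, and it is a large one: the measured solubility of compound 1, 1200 ug/mL, and of compound 3, 39000 ug/mL, a 33-fold higher number (1.51 log units; beyond the scatter). Going by these compounds, whether a carboxylic acid or a longer chain on this carbon would shift either number in the same way remains open.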